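The source may hold more compounds than are shown below. What is called first, only, known or untested is meant among the compounds shown, and "the series" means these compounds.

Measured so far in a functional assay on A-431 cells (Homo sapiens) for antiproliferative activity, read by MTT assay, with a stated time of 72 h; on this read-out higher numbers stand for weaker inhibition and lower numbers for stronger inhibition:
compound 1 `O=C(Nc1ccc(CN2CCCC2)cc1)Nc1ccc2ncnc(Nc3cccc(C(F)(F)F)c3)c2c1`, 1360 nM
compound 2 `O=C(Nc1cccc(CN2CCCC2)c1)Nc1ccc2ncnc(Nc3cccc(C(F)(F)F)c3)c2c1`, 1230 nM
compound 3 `Cc1ccc(NC(=O)Nc2ccc3ncnc(Nc4cccc(C(F)(F)F)c4)c3c2)cc1`, > 10000 nM

Compound 3 sits at the limit of > 10000 nM in this assay, at which 1 of the 3 values shown sits; its entry is a limit of this assay, not a number. Among the measured steps, a 1.1-fold lower number from compound 1 to compound 2 (0.04 log units; within the scatter) shows that moving the (pyrrolidin-1-yl)methyl group between ring positions changes nothing beyond the scatter, whereas an at least 7.3-fold higher number from compound 1 to compound 3 (0.86 log units; beyond the scatter) and an at least 8.1-fold higher number from compound 2 to compound 3 (0.91 log units; beyond the scatter) show that replacing the pyrrolidin-1-yl-bearing phenyl by 4-methylphenyl pushes the value past the limit.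

Compound 4 `CN1CCN(CCNC(=O)Nc2ccc3ncnc(Nc4cccc(C(F)(F)F)c4)c3c2)CC1` differs from compound 3 by 2-(4-methylpiperazin-1-yl)ethyl in place of 4-methylphenyl on an amide-type nitrogen. This change again brings in a saturated amine ring, here as 4-methylpiperazin-1-yl on an ethyl chain rather than pyrrolidin-1-yl on a benzylic carbon, and the aromatic ring on the amide-type nitrogen is lost. Among the measured compounds shown here, the two steps into compound 3 are the only guide, and they run in the direction of recovery when such a ring is present, so for compound 4 a drop in the number is expected, around an at least 3.3-fold lower number from compound 3 to compound 4 (0.52 log units; beyond the scatter), though the loss of the aromatic ring has no measured counterpart here and widens the range. Compound 4 is therefore estimated at 3000 nM, between 800 nM and 15000 nM.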

Compound 4, half-maximal inhibitory concentration: > 10000 nM
Compound 4 ended at the assay's limit; the forecaster's own chance of this, stated with the estimate: 30%; middle value at least 3.3-fold (0.52 log units) from the limit.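

In this assay compound 4 gives > 10000 nM, which is a limit of the assay and not a number, so the step between compound 3 and compound 4 cannot be read, and the series now has two entries at that limit: the limit of > 10000 nM in this assay, at which 2 of the 4 values shown sit.

The readable steps are an at least 7.3-fold higher number from compound 1 to compound 4 (0.86 log units; beyond the scatter) and an at least 8.1-fold higher number from compound 2 to compound 4 (0.91 log units; beyond the scatter), each with 2-(4-methylpiperazin-1-yl)ethyl on the amide-type nitrogen in place of a phenyl group carrying a (pyrrolidin-1-yl)methyl group. Compound 4 goes against the link suggested by compound 1, compound 2 and compound 3, so a saturated amine ring on this side of the urea is not sufficient on its own to keep the value clear of the limit.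

On these data alone, the change swaps the amine ring and removes the aromatic ring at once, and which of these matters remains open. A 2-(pyrrolidin-1-yl)ethyl chain or a 4-((4-methylpiperazin-1-yl)methyl)phenyl group at this place would separate the two.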